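From piperidin-3-yl to oxan-4-yl on a shared core

A few compounds are considered here, and "the series" means these few. Any claim that something is new, unique, unknown or untested is made for them only; others in the source may bear on it.

In an ADME assay on microsomes from liver (Rattus norvegicus) for metabolic stability, read by LC-MS, tested at 1 uM (a lower number here means that the compound disappears faster, a higher number that the compound lasts longer), compound 3 (`Nc1ncnc2c1c(Oc1cccc(Cl)c1)nn2CC1CCCNC1`) gives > 1 h, which is a limit and not a number. Compound 1 (`CN1CCC(Cn2nc(Oc3cccc(Cl)c3)c3c(N)ncnc32)CC1`) gives > 1 h, also a limit. Compound 2 (`Nc1ncnc2c1c(Oc1cccc(Cl)c1)nn2CC1(C(F)(F)F)CC1`) alone gives a measured number, 0.183 h, as its half-life. Compound 4 (`Nc1ncnc2c1c(Oc1cccc(Cl)c1)nn2CC1CCOCC1`) carries oxan-4-yl in place of piperidin-3-yl on a saturated chain carbon bound to an aromatic nitrogen. Among the measured compounds shown here, two steps bear on this: an at least 5.4-fold lower number from compound 1 to compound 2 (0.73 log units; beyond the scatter) and an at least 5.4-fold higher number from compound 2 to compound 3 (0.73 log units; beyond the scatter) both involve compound 2, whose group, like oxan-4-yl, holds no nitrogen. A lower number of modest size is therefore expected, namely an at least 2.0-fold lower number from compound 3 to compound 4 (0.30 log units; that floor lies within the scatter) in this estimate. The estimated half-life of compound 4 is 0.5 h (expected range 0.2 h to 1.2 h).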

Compound 4, half-life: 0.233 h
The estimate for compound 4 lay 2.1-fold (0.33 log units) above the measured number; the measured number falls inside the stated range.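

In this assay, oxan-4-yl on this chain carbon gives an at least 4.2-fold lower number from compound 3 to compound 4 (0.63 log units; beyond the scatter), and the picture is the same against the methylated ring with an at least 4.2-fold lower number from compound 1 to compound 4 (0.63 log units; beyond the scatter). Against the other group without nitrogen it gives a 1.3-fold higher number from compound 2 to compound 4 (0.10 log units; within the scatter), so the two nitrogen-free compounds cannot be told apart, while both nitrogen-bearing compounds sit apart from them, with no compound shown going against this. Those two larger steps are only floors because compound 1 and compound 3 each rest on a limit: the limit of > 1 h in this assay, at which 2 of the 4 values shown sit.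

Still open, as far as these compounds go, is whether the nitrogen must sit in a ring, which an open-chain amine at this place would test. A carboxylic acid there remains equally unknown.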